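Swapping phenyl for hydrogen on compound 2

The compounds below may be only part of what the source reports. "The series", "measured", "known", "first", "only" and "open" are said of these compounds alone.

compound 1 `N[C@H](CSCc1ccccc1)[C@@H]1CC(Br)=NO1`: "not determined" (no result reported)
compound 2 `N[C@H](C(=O)OCc1ccccc1)[C@@H]1CC(Br)=NO1`: > 65000 nM
compound 3 `N[C@H](CSCc1ccccc1)[C@H]1CC(Br)=NO1`: "not determined" (no result reported)

These compounds were examined in an ADME assay on HMEC-1 cells (Homo sapiens) for cytotoxicity, read by MTT assay, with a stated time of 72 h; a higher number here means a weaker inhibitor, a lower number a stronger inhibitor. In this assay compound 2 gives > 65000 nM, which is a limit of the assay and not a number. Among the measured compounds shown here, it is the only entry with any reading, and its position is fixed solely by the limit of > 65000 nM in this assay, at which 1 of the 3 values shown sits. Compound 1 and compound 3 add no result to compare with it. What can be said of that pair is the fact that compounds 1 and 3 differ only in the configuration as drawn.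

The next compound to be measured is compound 4 `COC(=O)[C@@H](N)[C@@H]1CC(Br)=NO1`. The change from compound 2 is hydrogen in place of phenyl on a saturated chain carbon bound to an oxygen next to a carbonyl group.

For the measured compounds named here, no pair of measured compounds carries this change, so the expectation rests on compound 2 alone, whose > 65000 nM is a limit. The expected size of the change is none beyond the usual scatter in either direction, and the estimated step is a step that the limit leaves unreadable from compound 2 to compound 4. A limit rather than a number is also a likely outcome. For compound 4 the estimated value is 80000 nM, with an expected range from 30000 nM to 200000 nM.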

Compound 4, half-maximal inhibitory concentration: 34800 nM
Beside the measured number, compound 4's estimate is 2.3-fold (0.36 log units) above it; low and high end bracket the measured number.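

In this assay compound 4 gives 34800 nM, a true number rather than a limit, so the series now has its first reading that can be placed on the scale. Putting hydrogen in place of phenyl on a saturated chain carbon bound to an oxygen next to a carbonyl group comes with an at least 1.8-fold lower number from compound 2 to compound 4 (0.27 log units; that floor lies within the scatter), so this position can be changed without losing the reading, but the step is only a minimum and does not by itself establish a real change. Its true size cannot be read, because one end of the step is a limit and not a number: the limit of > 65000 nM in this assay, at which 1 of the 4 values shown sits.

What the compounds shown leave open is how far the reading moves at this position, and whether an ethyl group, a longer chain or a second ring in place of the phenyl would give a number on the same scale. Also open, going by these compounds, is whether a carboxylic acid in place of this ester would change the reading, and whether the drawn configuration matters, since compound 1 and compound 3 offer no result to compare.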